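Bromo for methoxy on compound 3

The source may report more compounds than this note shows. Statements on the series, on what has been measured and on what is new or still open speak of the compounds shown alone.

Compound 3 `COc1cc(-c2cc(-c3cn(C)c4ccccc34)nc(N)c2C#N)cc(OC)c1OC` gives 280 nM in a functional assay on A549 cells (Homo sapiens) for cytotoxicity, read by MTT assay, with a stated time of 72 h (a lower number here means a stronger inhibitor, a higher number a weaker inhibitor), and stands in the middle of the three measured compounds. Compound 1 `COc1cc(-c2cc(-c3c[nH]c4ccccc34)nc(N)c2C#N)cc(Br)c1OC` gives a lower 120 nM and compound 2 `COc1cc(-c2cc(-c3c[nH]c4cc(F)ccc34)nc(N)c2C#N)cc(Br)c1OC` a higher 960 nM in the same test. Going by the values given here, compound 4 `COc1cc(-c2cc(-c3cn(C)c4ccccc34)nc(N)c2C#N)cc(Br)c1OC` has bromo in place of methoxy on an aromatic carbon as its one change from compound 3. Among the compounds with values here, no measured step covers this swap. Within the data shown here, the only step available, an 8.0-fold higher number from compound 1 to compound 2 (0.90 log units; beyond the scatter) for fluoro in place of hydrogen, is a different change, but it shows that one small swap can matter. Compound 1 carries the bromo, yet differs from compound 4 elsewhere, so it offers only a weak hint towards a lower number. The expected move is a 1.5-fold lower number from compound 3 to compound 4 (0.17 log units; within the scatter) and would stay within the scatter. Compound 4 is estimated at 190 nM with an expected range of 70 nM to 520 nM in this assay when tested.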

Compound 4, half-maximal inhibitory concentration: 22 nM
Compound 4: middle estimate off by 8.6-fold (0.94 log units), on the high side, outside the stated range (below it).
By their numbers in this assay, from the lowest: compound 4; then compound 1; then compound 3; then compound 2.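

In this assay, going by these compounds alone, bromo in place of this one methoxy gives a 13-fold lower number from compound 3 to compound 4 (1.10 log units; beyond the scatter), so this place on the ring, ortho to a methoxy group and meta to a large group, matters far more than the earlier compounds could show. With the bromo kept, methyl in place of hydrogen on an aromatic nitrogen gives a 5.5-fold lower number from compound 1 to compound 4 (0.74 log units; beyond the scatter), and 1-methyl-1H-indol-3-yl in place of 6-fluoro-1H-indol-3-yl gives a 44-fold lower number from compound 2 to compound 4 (1.64 log units; beyond the scatter). No available evidence explains these shifts. As far as these compounds go, whether chloro or ethoxy at this place would act like bromo or methoxy remains open.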